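An Ethoxy Group Joins the Pyrrole-Bearing Compound

This account rests on a few compounds, and the source may have more. Where it says the series, first, only, none or still open, it means among the compounds named here.

Within the data shown here, in a functional assay on CHO cells for agonist activity at Free fatty acid receptor 1 (Homo sapiens), read by FLIPR and calcium flux, with a stated time of 90 s (a lower number here means that less compound is needed, a higher number that more compound is needed for the effect), compound 2 `Cc1ccc(C)n1-c1cccc(COc2ccc3c(c2)OCC3CC(=O)O)c1` gives 46.9 nM, the higher of the two numbers measured so far. Compound 1 `Cc1cccc(C)c1-c1cccc(COc2ccc3c(c2)OCC3CC(=O)O)c1` gives 38.4 nM in this assay. The gap between them, a 1.2-fold higher number from compound 1 to compound 2 (0.09 log units; within the scatter), stays within the scatter. Compound 3 `CCOc1ccc(COc2ccc3c(c2)OCC3CC(=O)O)cc1-n1c(C)ccc1C` has not yet been measured; it differs from compound 2 by ethoxy in place of hydrogen on an aromatic carbon. Among the measured compounds shown here, no measured step shows what an ethoxy group does at this place; the one step on hand concerns another position and was within the scatter. A small step is therefore expected, a 1.2-fold lower number from compound 2 to compound 3 (0.07 log units; within the scatter). Compound 3 is estimated at 40 nM, with a range from 15 nM to 120 nM.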

Compound 3, half-maximal effective concentration: 61.2 nM
For compound 3 the middle estimate is 1.5-fold (0.18 log units) below the measured one; the measured number falls inside the stated range.
By their numbers in this assay, from the lowest: compounds 1, 2 and 3 (each within the scatter of the next).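

In this assay, adding ethoxy on the aromatic carbon ortho to the 2,5-dimethyl-1H-pyrrol-1-yl group gives a 1.3-fold higher number from compound 2 to compound 3 (0.12 log units; within the scatter) and so leaves compound 3 indistinguishable from compound 2. Among these compounds, this is the first reading at this position, and it shows that these 3 added heavy atoms can sit here without a step beyond the scatter. No measurement on hand offers a reason for this result. Open, on these data alone, is whether an amine or a longer chain, such as butoxy, would behave the same way at this position. Also open, as far as these compounds go, is whether ethoxy would give a similar step with 2,6-dimethylphenyl in place of the pyrrole group.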